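Aryl for Benzyl on the Cyanoguanidine Nitrogen

This account rests on a few compounds, and the source may have more. Where it says the series, first, only, none or still open, it means among the compounds named here.

Measured compounds in a functional assay (aorta) with Rattus norvegicus as the target; a lower number here means a stronger inhibitor, a higher number a weaker inhibitor:
compound 1, `CC1(C)Oc2ccc(C#N)cc2[C@@H](/N=C(\NC#N)NCc2ccccc2)[C@@H]1O`: 2400 nM
compound 2, `CC1(C)Oc2ccc(C#N)cc2[C@@H](NC(=O)Nc2ccncc2)[C@@H]1O`: 8500 nM
compound 3, `COC(=O)c1cc2ccccc2n1[C@@H]1c2cc(C#N)ccc2OC(C)(C)[C@H]1O`: 33100 nM

Compound 1 holds the lowest number of the three, with its half-maximal inhibitory concentration of 2400 nM. Compound 2, at 8500 nM, sits nearest, yet beyond the scatter, and compound 3, at 33100 nM, is furthest away. The next compound, compound 4 (`Cc1ccc(N/C(=N/[C@@H]2c3cc(C#N)ccc3OC(C)(C)[C@H]2O)NC#N)cc1`), keeps every atom of compound 1 and differs only in how they are joined: 4-methylphenyl in place of benzyl on an amine nitrogen. For the measured compounds named here, no pair of measured compounds shows this change, so its effect is not known from the data. A modest lowering of the number is expected in this assay, as a 2.4-fold lower number from compound 1 to compound 4 (0.38 log units; beyond the scatter). Compound 4 is therefore estimated at 1000 nM, within a range of 300 nM to 5000 nM.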

Compound 4, half-maximal inhibitory concentration: 2700 nM
For compound 4 the middle estimate is 2.7-fold (0.43 log units) below the measured one; the measured number falls inside the stated range.
By their numbers in this assay, from the lowest: compounds 1 and 4 (each within the scatter of the next); then compound 2; then compound 3.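

In this assay, 4-methylphenyl in place of benzyl on an amine nitrogen gives a 1.1-fold higher number from compound 1 to compound 4 (0.05 log units; within the scatter). The cyanoguanidine nitrogen of the core thus carries either group, attached through a methylene or directly through the ring, with no difference that stands out from the scatter. Nothing available explains why the two groups read alike. The compounds shown leave open whether a chlorophenyl group, a phenylethyl chain or a cyclohexyl group on this nitrogen would keep the number at this level.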